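Pendant acid chain on the benzoyl ring of compound 1

A few compounds are considered here, and "the series" means these few. Any claim that something is new, unique, unknown or untested is made for them only; others in the source may bear on it.

Compound 1 `O=C(NN1CCc2ccccc21)c1ccccc1` is the unsubstituted parent of this small set. In an assay on RBL-1 cells for inhibition of Polyunsaturated fatty acid 5-lipoxygenase (Rattus norvegicus), tested at 10 uM (on this read-out higher numbers stand for more inhibition at the one concentration tested (going by the name of the read-out) and lower numbers for less inhibition), compound 1 gives 15%, the lowest of the three numbers recorded. Its nearest neighbour is compound 3 `COc1ccc2c(c1)CCN2NC(=O)c1ccccc1`, which in this assay gives 20%, a gap within the scatter. The furthest is compound 2 `CN(NC(=O)c1ccccc1)c1ccccc1`, a ring-opened analogue carrying a methyl on the hydrazide nitrogen, which in this assay gives 28%, a gap beyond the scatter.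

Compound 4 `O=C(O)CCC/C=C/c1ccc(C(=O)NN2CCc3ccccc32)cc1` carries the change 5-carboxypent-1-en-1-yl in place of hydrogen on an aromatic carbon relative to compound 1. Within the data shown here, of the measured steps, only the one from compound 1 to compound 3 a number 5 percentage points higher from compound 1 to compound 3 (within the scatter) involves a substituent entering on an aromatic carbon, and it did not move the read-out beyond the scatter; it also sits on a different ring of the shared core, so its bearing on compound 4 is indirect. Compound 2 differs from compound 1 in the hydrazide part, not on an aromatic carbon, and adds nothing on this point. Among the measured compounds shown here, no measured step places an acid-bearing chain anywhere.

On this basis compound 4 is expected to stay near compound 1, with the step of a number 7 percentage points higher from compound 1 to compound 4 (within the scatter) estimated as no more than the scatter. The estimate for compound 4 in this assay is 22%, in the range 5% to 45%.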

Compound 4, a percentage reported as inhibition, at one concentration (the size of the read-out at that concentration, not a potency): 18%
Compound 4: middle estimate off by 4 percentage points, on the high side; measured number inside the range.
By their numbers in this assay, from the lowest: compounds 1, 4, 3 and 2 (each within the scatter of the next, the first and the last beyond it).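

In this assay, the position para to a large group on the six-membered aromatic ring of carbon only takes the 5-carboxypent-1-en-1-yl chain with a number 3 percentage points higher from compound 1 to compound 4 (within the scatter) and no change beyond the scatter, so a chain of this size ending in a carboxylic acid leaves the read-out where the unsubstituted parent has it. The earlier compounds shown here offered only the small methoxy step, a number 5 percentage points higher from compound 1 to compound 3 (within the scatter) and no information on this position or on any chain, so the flat result here is new, though it is flat at a low level of inhibition. Nothing available explains why the chain leaves the number in place.

From the compounds shown here alone, whether a shorter chain, a saturated chain, or an amine or methyl ester in place of the carboxylic acid at this position would give a step beyond the scatter remains open. Also open, going by these compounds, is whether the same 5-carboxypent-1-en-1-yl chain would behave alike on compound 2, which gives 28% in this assay and so starts from a number beyond the scatter of compound 1.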